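Shortening the Alkoxy Chain: From Compound 3 to Compound 4

A few compounds are considered here, and "the series" means these few. Any claim that something is new, unique, unknown or untested is made for them only; others in the source may bear on it.

Three analogues share one core and differ only in the chain attached through an oxygen on an aromatic ring. In a functional assay for inhibition of Vanilloid receptor (Rattus norvegicus) (a lower number here means a stronger inhibitor, a higher number a weaker inhibitor), compound 1 `CCCOc1cc(C(C)(C)C)ccc1C/N=C(\S)NCc1ccc(NS(C)(=O)=O)cc1` gives 250 nM, compound 2 `CCCCOc1cc(C(C)(C)C)ccc1C/N=C(\S)NCc1ccc(NS(C)(=O)=O)cc1` gives 60 nM, and compound 3 `CCCCCCOc1cc(C(C)(C)C)ccc1C/N=C(\S)NCc1ccc(NS(C)(=O)=O)cc1` gives 150 nM. Compound 3 thus holds the second highest of the three numbers: it sits within the scatter of compound 1 (a 1.7-fold lower number from compound 1 to compound 3 (0.22 log units; within the scatter)), while its gap to compound 2 is beyond it (a 2.5-fold higher number from compound 2 to compound 3 (0.40 log units; beyond the scatter)). Compound 4 `COCOc1cc(C(C)(C)C)ccc1C/N=C(\S)NCc1ccc(NS(C)(=O)=O)cc1` alters the same chain: methoxy in place of pentyl on a saturated chain carbon bound to an oxygen on an aromatic ring. All three measured steps concern this chain. Lengthening it gave a 4.2-fold lower number from compound 1 to compound 2 (0.62 log units; beyond the scatter), yet lengthening further gave a 2.5-fold higher number from compound 2 to compound 3 (0.40 log units; beyond the scatter), so the middle length produced the lowest number. Within the data shown here, no measured compound carries a chain shorter than propyl or an oxygen inside the chain, so the direction is uncertain, and a number near or above that of compound 1 seems most plausible. Compound 4 is therefore expected to come in at 400 nM, with a range from 120 nM to 1500 nM. The expected shift is a 2.7-fold higher number from compound 3 to compound 4 (0.43 log units; beyond the scatter).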

Compound 4, half-maximal inhibitory concentration: 500 nM
Compound 4: middle estimate off by 1.3-fold (0.10 log units), on the low side; low and high end bracket the measured number.
By their numbers in this assay, from the lowest: compound 2; then compounds 3, 1 and 4 (each within the scatter of the next, the first and the last beyond it).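

In this assay, replacing hexyloxy with methoxymethoxy gives a 3.3-fold higher number from compound 3 to compound 4 (0.52 log units; beyond the scatter), and the gap to the butoxy chain of compound 2 is the widest step seen so far in this series: an 8.3-fold higher number from compound 2 to compound 4 (0.92 log units; beyond the scatter). Against the propoxy chain, no difference can be claimed, with a 2.0-fold higher number from compound 1 to compound 4 (0.30 log units; within the scatter), so this chain with an oxygen inside it does not reach the low number of compound 2. Nothing available explains these differences.

Chain length and the inner oxygen change together in compound 4, so the share of each in its number stays unknown. An ethoxy chain would test length alone, and a methoxyethoxy chain, closer in length to the butoxy chain, would show how an inner oxygen fares there.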